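The source may report more compounds than this note shows. Statements on the series, on what has been measured and on what is new or still open speak of the compounds shown alone.

Within the data shown here, the three compounds measured so far share one core. Compound 1 `O=C(/C=C/c1ccccc1)Nc1nnc(-c2ccc(Cl)cc2)s1` gives 2.02 ug/mL in a functional assay on A549 cells (Homo sapiens) for antiproliferative activity, read by MTT assay, with a stated time of 48 h; on this read-out lower numbers stand for stronger inhibition and higher numbers for weaker inhibition. Compound 2 `O=C(/C=C/c1ccccc1)Nc1nnc(-c2ccccc2)s1` gives 1.75 ug/mL in this assay, and compound 3 `Cc1ccc(-c2nnc(NC(=O)/C=C/c3ccccc3)s2)cc1` gives 1.38 ug/mL in this assay. Compound 2 stands second highest of the three numbers; its nearest neighbour is compound 1, separated by a 1.2-fold lower number from compound 1 to compound 2 (0.06 log units; within the scatter), and its furthest is compound 3, separated by a 1.3-fold lower number from compound 2 to compound 3 (0.10 log units; within the scatter). The remaining step, a 1.5-fold lower number from compound 1 to compound 3 (0.17 log units; within the scatter), is also within the scatter, so the three numbers cannot be told apart.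

Compound 4 `O=C(/C=C/c1ccc(C(F)(F)F)cc1)Nc1nnc(-c2ccccc2)s1` differs from compound 2 by trifluoromethyl in place of hydrogen on an aromatic carbon. Among the measured compounds shown here, none of the measured steps is this change: each of the three steps so far exchanged one small group for another on an aromatic carbon, and each stayed within the scatter. For the measured compounds named here, there is therefore no direct precedent, and what the measured steps do show is that single changes on an aromatic carbon have so far left the number unchanged within the scatter. Compound 4 is therefore expected to give a number close to that of compound 2, with a 1.0-fold higher number from compound 2 to compound 4 (0.01 log units; within the scatter) expected to lie within the scatter, in no particular direction. The estimate for compound 4 is 1.8 ug/mL, with a range from 0.9 ug/mL to 3.6 ug/mL.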

Compound 4, half-maximal inhibitory concentration: 1.78 ug/mL
Compound 4: middle estimate off by 1.0-fold (0.00 log units), on the high side; the measured number falls inside the stated range.
By their numbers in this assay, from the lowest: compounds 3, 2, 4 and 1 (each within the scatter of the next).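

In this assay, among these compounds, the step of a 1.0-fold higher number from compound 2 to compound 4 (0.01 log units; within the scatter) is the first in this set taken on the other six-membered aromatic ring of carbon only, the one left unchanged by the steps among compounds 1, 2 and 3. It also brings in a larger group than those earlier steps, since trifluoromethyl has 4 heavy atoms where hydrogen has none, yet compound 2 and compound 4 still cannot be told apart, so the insensitivity seen so far now extends to this second ring and to this larger group at this one place. Nothing given here offers an explanation for this result, as no accompanying measurement bears on it.

From the compounds shown here alone, what stays open is whether any group at this place can move the number beyond the scatter, for instance an amine, a carboxylic acid or a longer chain in place of the hydrogen of compound 2. Also open, going by these compounds, is whether trifluoromethyl would behave the same way at another carbon of this ring, or on the ring that carries the chloro group in compound 1.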